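Triazole-linked lactam series: aryl variation, compound 4 estimate

This account rests on a few compounds, and the source may have more. Where it says the series, first, only, none or still open, it means among the compounds named here.

Measured so far:
compound 1 `Cc1ccc(-n2cc(CN3C(=O)C[C@@H]4CC[C@@]3(C)C4(C)C)nn2)cc1`, 40 nM
compound 2 `CC1(C)[C@H]2CC[C@]1(C)N(Cc1cn(-c3ccc(C#N)cc3)nn1)C(=O)C2`, 380 nM
compound 3 `CC1(C)[C@H]2CC[C@]1(C)N(Cc1cn(-c3ccccc3F)nn1)C(=O)C2`, 300 nM

In a functional assay on OVCAR-3 cells (Homo sapiens) for inhibition, read by MTT assay, with a stated time of 24 h (a higher number here means a weaker inhibitor, a lower number a stronger inhibitor), compound 3 sits second highest of the three numbers; its nearest neighbour is compound 2, a difference within the scatter (a 1.3-fold lower number from compound 2 to compound 3 (0.10 log units; within the scatter)), and its furthest is compound 1 (a 7.5-fold higher number from compound 1 to compound 3 (0.88 log units; beyond the scatter)), beyond the scatter. Compound 4 `Cc1cccc(-n2cc(CN3C(=O)C[C@@H]4CC[C@@]3(C)C4(C)C)nn2)c1` is not yet measured. The change: 3-methylphenyl in place of 2-fluorophenyl on an aromatic nitrogen. For the measured compounds named here, the steps that bear on it are a 7.5-fold higher number from compound 1 to compound 3 (0.88 log units; beyond the scatter) and a 9.5-fold higher number from compound 1 to compound 2 (0.98 log units; beyond the scatter), both modest and both moving away from the methyl-bearing compound 1. Returning to a methylphenyl, though at a different ring position, compound 4 is expected to step back toward compound 1, by about a 3.0-fold lower number from compound 3 to compound 4 (0.48 log units; beyond the scatter). Compound 4 is therefore estimated at 100 nM, within 35 nM to 300 nM.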

Compound 4, half-maximal inhibitory concentration: 160 nM
Compound 4: the middle estimate sits 1.6-fold (0.20 log units) below what was measured; measured number inside the range.
By their numbers in this assay, from the lowest: compound 1; then compounds 4, 3 and 2 (each within the scatter of the next, the first and the last beyond it).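

In this assay, moving from 4-methylphenyl to 3-methylphenyl on the aromatic nitrogen is a step beyond the scatter (a 4.0-fold higher number from compound 1 to compound 4 (0.60 log units; beyond the scatter)), so a methylphenyl as such does not carry the value of compound 1. The 3-methylphenyl is not separated from 2-fluorophenyl (a 1.9-fold lower number from compound 3 to compound 4 (0.27 log units; within the scatter)) but is separated from 4-cyanophenyl (a 2.4-fold lower number from compound 2 to compound 4 (0.38 log units; beyond the scatter)). No measured property bears on these steps.

Still open, going by these compounds, is whether a larger group on the phenyl ring, such as an ethyl or a methoxy, holds the value of compound 1. An amine or a carboxylic acid there also remains untested in the compounds shown.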